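One Ring Centre Inverted: From Compound 2 to Compound 3

The source may report more compounds than this note shows. Statements on the series, on what has been measured and on what is new or still open speak of the compounds shown alone.

Going by the values given here, compound 2, `O=C(NO)[C@H]1C[C@@H](OCc2ccccc2)CN1S(=O)(=O)c1ccc(Cl)c(Cl)c1`, is the only compound in this small set with a number to its name. In an assay on isolated protein for inhibition of matrix metalloproteinase-9 (Homo sapiens), read by fluorescence, with stated times of 5 min and 30 min, tested at 5 uM (on this read-out higher numbers stand for more inhibition at the one concentration tested (going by the name of the read-out) and lower numbers for less inhibition), compound 2 gives 97%, a high number on this read-out. Compound 1, `O=C(N[C@H]1C[C@H](C(=O)NO)N(S(=O)(=O)c2ccc(Cl)c(Cl)c2)C1)c1cccs1`, was tested in this assay as well and is recorded as "not active" (no number reported), so no number is attached to it and nothing can be said about a step between the two.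

Compound 3, `O=C(NO)[C@H]1C[C@H](OCc2ccccc2)CN1S(=O)(=O)c1ccc(Cl)c(Cl)c1`, is now to be measured in this assay. Set against compound 2, the change is the two compounds have the same atoms and bonds and differ only in configuration as drawn: 1 of 2 stereo elements differ; a stereocentre at a saturated ring carbon is drawn R in compound 2 and S in compound 3. Among the compounds with values here, no step between measured compounds is available to show how such a change plays out here, so the expectation rests on compound 2 alone. Since compound 2 gives 97%, a high number at the one concentration tested, compound 3 is expected to keep a high number while giving up some of it: the estimate for compound 3 is 84%, with a range from 55% to 99%. This estimate means a step of a number 13 percentage points lower from compound 2 to compound 3 (beyond the scatter), a fall expected to reach just beyond the usual scatter.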

Compound 3, a percentage reported as inhibition, at one concentration (the size of the read-out at that concentration, not a potency): 37%
For compound 3 the middle estimate is 47 percentage points above the measured one, outside the stated range (below it).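

Inverting a single stereocentre at a saturated ring carbon is enough on its own to give a number 60 percentage points lower from compound 2 to compound 3 (beyond the scatter) in this assay, so what matters at this position is not only which atoms are present but also how they are arranged in space. The earlier compounds shown here could not show this: only compound 2 carried a number, and with no step to read, the effect of configuration at this carbon was unknown. The fall can be assigned to the inverted stereocentre alone, because no other difference separates the pair: the fact that compounds 2 and 3 differ only in the configuration as drawn

The compounds shown leave open whether the S arrangement would cost as much with a different group at this carbon, such as an amine or a simple hydroxyl, and what inverting the other stereocentre would do. From the compounds shown here alone, the read-out is also taken at one concentration and is not a potency, so it remains open how large the change would be if expressed as a potency, or whether it would carry over to other matrix metalloproteinases.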